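The source may hold more compounds than are shown below. What is called first, only, known or untested is meant among the compounds shown, and "the series" means these compounds.

Of the compounds shown here, three sharing one core have been measured in a functional assay on MCF7 cells (Homo sapiens) for cytotoxicity, read by sulforhodamine B assay, with a stated time of 24 h (a higher number here means a weaker inhibitor, a lower number a stronger inhibitor), namely compound 1 (`Cc1ccc(S(=O)(=O)N/N=C2\C(=O)Nc3ccc(S(=O)(=O)N4CCOCC4)cc32)cc1`), compound 2 (`O=C1Nc2ccc(S(=O)(=O)N3CCOCC3)cc2/C1=N/NC(=O)c1ccccc1`) and compound 3 (`O=C1Nc2ccc(S(=O)(=O)N3CCOCC3)cc2/C1=N/Nc1ccccc1`). Compound 3 gives 30300 nM there and compound 1 gives 38400 nM there, which places the two within the scatter of each other. Compound 2 gives 414000 nM by contrast, and the measured gap (a 14-fold lower number from compound 2 to compound 3 (1.14 log units; beyond the scatter)) is large. Still unmeasured is compound 4 (`O=C1Nc2ccc(S(=O)(=O)N3CCOCC3)cc2/C1=N/NS(=O)(=O)c1ccccc1`), which has phenylsulfonyl in place of phenyl on an amine nitrogen. Compound 1 bears most directly on this change: it too carries a sulfonyl group on that nitrogen, as (4-methylphenyl)sulfonyl, and the exchange of that group for phenyl (a 1.3-fold lower number from compound 1 to compound 3 (0.10 log units; within the scatter)) stayed within the scatter. The large step involving benzoyl (an 11-fold higher number from compound 1 to compound 2 (1.03 log units; beyond the scatter)) concerns a group that compound 4 does not carry, so it offers less guidance here. In this assay no step beyond the scatter is therefore expected, and the estimated change is small (a 1.3-fold higher number from compound 3 to compound 4 (0.10 log units; within the scatter)), with any drift expected toward a slightly higher number. Compound 4 is expected at 38000 nM (estimated range 16000 nM to 90000 nM).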

Compound 4, half-maximal inhibitory concentration: 25300 nM
Estimate against measurement, compound 4: 1.5-fold (0.18 log units) above, and the stated range covers the measured number.
By their numbers in this assay, from the lowest: compounds 4, 3 and 1 (each within the scatter of the next); then compound 2.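

In this assay, putting phenylsulfonyl in place of phenyl on the amine nitrogen gives a 1.2-fold lower number from compound 3 to compound 4 (0.08 log units; within the scatter), so this direct comparison shows that the two groups cannot be told apart at this position, although the sulfonyl unit adds hydrogen-bond acceptors to the substituent. The methyl group on the aromatic ring of the sulfonyl substituent is now isolated as a single change, and its replacement by hydrogen gives a 1.5-fold lower number from compound 1 to compound 4 (0.18 log units; within the scatter), which also leaves the read-out within the scatter. Against the unsubstituted phenylsulfonyl group, benzoyl gives a 16-fold lower number from compound 2 to compound 4 (1.21 log units; beyond the scatter), which, with the earlier steps, sets compound 2 apart as the weakest of the four, with compound 1, compound 3 and compound 4 forming one group.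

The data shown offer no measurement that explains why benzoyl alone stands apart from the other groups on this nitrogen. From the compounds shown here alone, every group here carries a six-membered aromatic ring, so it remains open whether a methylsulfonyl or acetyl group would follow phenylsulfonyl or benzoyl, and whether a methoxy group or chlorine on the ring would move the number any more than methyl does.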